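Butylamino in place of morpholin-4-yl

This account rests on a few compounds, and the source may have more. Where it says the series, first, only, none or still open, it means among the compounds named here.

Four compounds share one core and differ in the group on a carbonyl carbon: compound 1 `Nc1sc(-c2ccc(Cl)cc2)c(-c2ccc(Cl)cc2)c1C(=O)N1CCCCC1=O`, compound 2 `Nc1sc(-c2ccc(Cl)cc2)c(-c2ccc(Cl)cc2)c1C(=O)NC1CCCCC1`, compound 3 `Nc1sc(-c2ccc(Cl)cc2)c(-c2ccc(Cl)cc2)c1C(=O)N1CCOCC1` and compound 4 `CCCCNC(=O)c1c(N)sc(-c2ccc(Cl)cc2)c1-c1ccc(Cl)cc1`. In a functional assay on PC-3 cells (Homo sapiens) for inhibition, read by sulforhodamine B assay, with a stated time of 72 h (on this read-out lower numbers stand for stronger inhibition and higher numbers for weaker inhibition), compound 1 gives 4940 nM, compound 2 gives 7300 nM and compound 3 gives 11700 nM. Compound 4 brings (butylamino in place of morpholin-4-yl on a carbonyl carbon). Compound 2 carries cyclohexylamino, the nearest match to butylamino, and swapping it for morpholin-4-yl gave only a 1.6-fold higher number from compound 2 to compound 3 (0.20 log units; within the scatter). Compound 1 stands further off, at a 2.4-fold higher number from compound 1 to compound 3 (0.37 log units; beyond the scatter). No step beyond the scatter is therefore expected in this assay. The estimated step is a 1.6-fold lower number from compound 3 to compound 4 (0.19 log units; within the scatter). For compound 4 the expected value is 7500 nM, with an estimated range from 3500 nM to 15000 nM.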

Compound 4, half-maximal inhibitory concentration: 17800 nM
The estimate for compound 4 lay 2.4-fold (0.38 log units) below the measured number; measured number above the stated range.
By their numbers in this assay, from the lowest: compounds 1, 2, 3 and 4 (each within the scatter of the next, the first and the last beyond it).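

In this assay, butylamino and morpholin-4-yl on the carbonyl carbon cannot be told apart (a 1.5-fold higher number from compound 3 to compound 4 (0.18 log units; within the scatter)). Butyl in place of cyclohexyl on the amide-type nitrogen does register (a 2.4-fold higher number from compound 2 to compound 4 (0.39 log units; beyond the scatter)), so keeping the amide hydrogen does not by itself hold the number. The widest step at this position separates butylamino from 2-oxopiperidin-1-yl (a 3.6-fold higher number from compound 1 to compound 4 (0.56 log units; beyond the scatter)).

No measurement shown explains these steps. On these data alone, whether a shorter chain such as ethylamino, or benzylamino, would sit nearer compound 2 or compound 4 stays open.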